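Swapping Chloro for Methyl on Compound 1

The compounds below may be only part of what the source reports. "The series", "measured", "known", "first", "only" and "open" are said of these compounds alone.

Compound 1, `O=C(Nc1nnc(-c2ccc3c(c2)OCCO3)s1)c1ccc(Cl)nc1`, gives 30.4 ug/mL in a functional assay on SW 1116 cells (Homo sapiens) for antiproliferative activity, read by MTT assay, with a stated time of 48 h; a lower number here means that less compound is needed, a higher number that more compound is needed for the effect. Compound 2, `O=C(/C=C/c1ccccc1)Nc1nnc(-c2ccc3c(c2)OCCO3)s1`, gives 60.2 ug/mL. Compound 3, `O=C(Nc1nnc(-c2ccc3c(c2)OCCO3)s1)c1ccncc1`, reaches only the limit > 100 ug/mL.

Among the two plain numbers, compound 1 holds the lower one, though the step of a 2.0-fold higher number from compound 1 to compound 2 (0.30 log units; within the scatter) is too small to rank the two against each other. The value of compound 3 is the limit of > 100 ug/mL in this assay, at which 1 of the 3 values shown sits, a limit and not a number. Among the compounds with values here, the shift an at least 3.2-fold higher number from compound 1 to compound 3 (0.51 log units; beyond the scatter) is the one step here that goes beyond the scatter, and it replaces the whole group on the carbonyl carbon.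

Compound 4, `Cc1ccc(C(=O)Nc2nnc(-c3ccc4c(c3)OCCO4)s2)cn1`, differs from compound 1 in one place: methyl in place of chloro on an aromatic carbon. Within the data shown here, no measured step keeps that ring and changes only a single substituent on it, so none bears on this change directly; the steps that do exist, a 2.0-fold higher number from compound 1 to compound 2 (0.30 log units; within the scatter) and an at least 1.6-fold higher number from compound 2 to compound 3 (0.22 log units; that floor lies within the scatter), exchange whole groups and say little about a single small substituent. In this assay a step within the scatter is therefore expected for compound 4. The estimate for compound 4 is 35 ug/mL, with a range from 15 ug/mL to 80 ug/mL, which means an expected step of a 1.2-fold higher number from compound 1 to compound 4 (0.06 log units; within the scatter).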

Compound 4, half-maximal effective concentration: > 100 ug/mL
Compound 4 gave a limit, no number; the forecaster's own chance of this, stated with the estimate: 12%; middle value at least 2.8-fold (0.45 log units) from the limit.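

Methyl for chloro is the first change here confined to a single substituent, one heavy atom for one heavy atom, on an aromatic carbon next to the ring nitrogen, and in this assay it gives an at least 3.2-fold higher number from compound 1 to compound 4 (0.51 log units; beyond the scatter). This position is therefore not indifferent to what stands on it, and a small exchange here moves the result beyond the scatter, which the earlier whole-group steps could not show. Compound 4 now shares with compound 3 a limit and not a number: the limit of > 100 ug/mL in this assay, at which 2 of the 4 values shown sit.

The remaining comparison, an at least 1.6-fold higher number from compound 2 to compound 4 (0.22 log units; that floor lies within the scatter), does not firmly separate those two compounds, and the step between compound 3 and compound 4 cannot be read. Going by these compounds, how far the true value of compound 4 lies past the limit stays open, so the full size of the change from 6-chloropyridin-3-yl to 6-methylpyridin-3-yl is unknown. Also open, on these data alone, is whether a fluoro, a methoxy or an amine at this same place would give a measurable number, or whether chloro alone among such small groups does.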